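The source may report more compounds than this note shows. Statements on the series, on what has been measured and on what is new or still open speak of the compounds shown alone.

Measured so far:
Compound 1 `COc1ccc(-n2c(CCc3ccccc3)nnc2[C@H](NC(=O)Cc2ccccn2)c2c[nH]c3ccccc23)c(OC)c1`: in an in vitro assay on LLC-PK1 cells for displacement of a labelled ligand from growth hormone secretagogue receptor type 1 (Homo sapiens) (on this read-out higher numbers stand for weaker inhibition and lower numbers for stronger inhibition), compound 1 gives 120 nM.
Compound 2 `COc1ccc(Cn2c(CCc3ccccc3)nnc2[C@H](NC(=O)Cc2ccccn2)c2c[nH]c3ccccc23)cc1`: in this assay compound 2 gives 3 nM.

Compound 1 stands highest of the two numbers in this assay; its nearest neighbour is compound 2, reached by a 40-fold lower number from compound 1 to compound 2 (1.60 log units; beyond the scatter). Compound 3 `COc1ccc(-n2c(CCc3ccccc3)nnc2[C@H](NC(=O)c2cnccn2)c2c[nH]c3ccccc23)c(OC)c1` differs from compound 1 in one place: pyrazin-2-yl in place of (pyridin-2-yl)methyl on a carbonyl carbon. Among the compounds with values here, the single measured step, a 40-fold lower number from compound 1 to compound 2 (1.60 log units; beyond the scatter), concerns the group on the aromatic nitrogen, not the carbonyl substituent, so no measured step bears on the present change. No shift beyond the scatter is therefore expected for compound 3 in this assay, in either direction. The estimate for compound 3 is 150 nM, with a range from 30 nM to 700 nM. This is expected to correspond to a 1.3-fold higher number from compound 1 to compound 3 (0.10 log units; within the scatter).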

Compound 3, half-maximal inhibitory concentration: 300 nM
For compound 3 the middle estimate is 2.0-fold (0.30 log units) below the measured one, within the range that was stated.
By their numbers in this assay, from the lowest: compound 2; then compound 1; then compound 3.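

The carbonyl substituent is not a silent position: in this assay, pyrazin-2-yl in place of (pyridin-2-yl)methyl gives a 2.5-fold higher number from compound 1 to compound 3 (0.40 log units; beyond the scatter) on the core of compound 1. This change moves the number less than the change on the aromatic nitrogen, which gave a 40-fold lower number from compound 1 to compound 2 (1.60 log units; beyond the scatter) in the same assay. No supporting data bear on the origin of the new step.

Still open, from the compounds shown here alone, is whether the ring or the methylene link carries the step; pyridin-2-yl or (pyrazin-2-yl)methyl on the carbonyl carbon would separate the two. Going by these compounds, whether the step holds with 4-methoxybenzyl on the aromatic nitrogen also remains open.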